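Notes on compound 1 and its fluoro analogue

The source may hold more compounds than are shown below. What is called first, only, known or untested is meant among the compounds shown, and "the series" means these compounds.

Three compounds of the series have numbers in an ADME assay on Vero cells (Chlorocebus sabaeus) for cytotoxicity, read by neutral red uptake, tested at 394 ug/mL; on this read-out higher numbers stand for a weaker effect at the one concentration tested and lower numbers for a stronger effect. Compound 1 `COc1ccc(C2SCC(=O)N2CCN2CCCCC2)cc1` gives 73% in that read-out. Compound 2 `O=C1CSC(c2cccc(Cl)c2)N1CCN1CCCCC1` gives 45%, and compound 3 `O=C1CSC(c2ccccc2[N+](=O)[O-])N1CCN1CCCCC1` gives 100%. Compound 1 therefore stands second highest of the three: the number for compound 3 lies beyond the scatter above it, and the number for compound 2 lies beyond the scatter below it, so the three measured compounds are separated from one another in this assay.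

Compound 4 `O=C1CSC(c2ccc(F)cc2)N1CCN1CCCCC1` has not yet been measured in this assay. It differs from compound 1 in one place: fluoro in place of methoxy on an aromatic carbon. Going by the values given here, no pair of measured compounds differing in one place exists, so there is no measured step to lean on for this change, and the expectation rests on the spread of the three numbers alone.

The expected step from compound 1 to compound 4 is a number 8 percentage points lower from compound 1 to compound 4 (within the scatter), small and most likely within the scatter. The gap between compound 2 at 45% and compound 3 at 100% shows how wide the range must be kept. Compound 4 is estimated to give 65% in this assay, within a range of 30% to 95%.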

Compound 4, a percentage reported as activity, at one concentration (the size of the read-out at that concentration, not a potency): 52%
The estimate for compound 4 lay 13 percentage points above the measured number, and the stated range covers the measured number.
By their numbers in this assay, from the lowest: compounds 2 and 4 (each within the scatter of the next); then compound 1; then compound 3.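

In this assay, going by these compounds alone, fluoro in place of methoxy on an aromatic carbon, para to a large group, gives a number 21 percentage points lower from compound 1 to compound 4 (beyond the scatter) and provides the first measured one-place step, showing that this single exchange can move the read-out beyond the scatter. The second new step, 4-fluorophenyl in place of 3-chlorophenyl on a saturated ring carbon, gives a number 7 percentage points higher from compound 2 to compound 4 (within the scatter) and so does not separate these two aryl groups in this read-out, even though the halogen and its place on the ring both differ. No measurement at hand accounts for either step.

Two steps cannot show whether the change from methoxy to fluoro reflects something particular to those two groups or a wider trend at this position, and a second group such as ethoxy, hydroxyl, an amine or a carboxylic acid in the same place would be needed to test that. On these data alone, it also remains open whether a chloro group in that same place would read like the fluoro group, which would separate the identity of the halogen from its place on the ring.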